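Methoxy to ethoxy on the naphthoquinone series: compound 4

The compounds below may be only part of what the source reports. "The series", "measured", "known", "first", "only" and "open" are said of these compounds alone.

Measured so far in a functional assay on DU-145 cells (Homo sapiens) for cytotoxicity, read by XTT assay, with a stated time of 24 h; a higher number here means a weaker inhibitor, a lower number a stronger inhibitor:
compound 1 `COc1cc(C)cc2c1C(=O)C=CC2=O` gives 30700 nM
compound 2 `CC(=O)Oc1cc(OC(C)=O)c2c(OC(C)=O)c(C)cc(Cl)c2c1OC(C)=O` gives 81600 nM
compound 3 `COc1cc(C)c(Cl)c2c1C(=O)C=CC2=O` gives 26600 nM

Compound 1 stands second highest of the three numbers. Its nearest neighbour is compound 3, reached by the step of a 1.2-fold lower number from compound 1 to compound 3 (0.06 log units; within the scatter), which is within the scatter. Among the compounds with values here, compound 2 stands furthest off, with a number beyond the scatter higher than that of compound 1; no single-point step links compound 2 to the others.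

Compound 4 `CCOc1cc(C)cc2c1C(=O)C=CC2=O` differs from compound 1 in one place: methyl in place of hydrogen on a saturated chain carbon bound to an oxygen on an aromatic ring. Within the data shown here, none of the measured steps touches this chain; the only step on this core, from compound 1 to compound 3, is within the scatter and concerns a different position. Nothing in the data shows that a larger alkoxy group should move the number in this assay in either direction, so the working expectation is a step of no more than the usual scatter, a 1.1-fold lower number from compound 1 to compound 4 (0.04 log units; within the scatter). Compound 4 is therefore estimated at 28000 nM, with a range from 11000 nM to 70000 nM.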

Compound 4, half-maximal inhibitory concentration: 15000 nM
The estimate for compound 4 lay 1.9-fold (0.27 log units) above the measured number; the range from low to high includes it.
By their numbers in this assay, from the lowest: compounds 4, 3 and 1 (each within the scatter of the next, the first and the last beyond it); then compound 2.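

The alkoxy chain on the shared core is a place where the number in this assay responds: methoxy to ethoxy gives a step beyond the scatter (a 2.0-fold lower number from compound 1 to compound 4 (0.31 log units; beyond the scatter)), whereas the earlier chloro in place of hydrogen stayed within it (a 1.2-fold lower number from compound 1 to compound 3 (0.06 log units; within the scatter)). The step is modest and rests on this single pair, so it shows only that the added methyl is tolerated on this chain and that the number falls with it. Nothing available explains this change in the number.

As far as these compounds go, whether the number keeps falling with a longer chain such as propoxy or butoxy, or with a branched one such as isopropoxy, remains open. Also open, from the compounds shown here alone, is how a chain ending in an amine or a carboxylic acid would behave, and whether ethoxy and chloro together on the shared core would give a further step.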